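The source may report more compounds than this note shows. Statements on the series, on what has been measured and on what is new or still open speak of the compounds shown alone.

The measured compounds:
Compound 1 `CNc1ccc(Nc2nccc(-c3cccnc3)n2)cc1` gives 2100 nM in a functional assay for inhibition, with Homo sapiens as the target; on this read-out lower numbers stand for stronger inhibition and higher numbers for weaker inhibition.
Compound 2 `NS(=O)(=O)c1ccc(Nc2nccc(-c3cccnc3)n2)cc1` gives 200 nM in this assay.
Compound 3 `NS(=O)(=O)c1ccc(Nc2nccc(-c3ccncc3)n2)cc1` gives 5100 nM in this assay.

Compound 3 stands at the highest number of the three, so it is the weakest inhibitor among them. Against compound 2 the gap is large: a 26-fold higher number from compound 2 to compound 3 (1.41 log units; beyond the scatter). Against compound 1 the values show compound 3 somewhat higher.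

Compound 4 `CC1CCN(c2ccc(Nc3nccc(-c4ccncc4)n3)cc2)CC1` has not yet been measured. It differs from compound 3 in one place: 4-methylpiperidin-1-yl in place of sulfamoyl on an aromatic carbon.

Among the measured compounds shown here, only one measured step speaks to this change. From compound 1 to compound 2, sulfamoyl took the place of methylamino on the aromatic carbon, and the number fell sharply: an 11-fold lower number from compound 1 to compound 2 (1.02 log units; beyond the scatter). In compound 4 the sulfamoyl leaves again, though what enters is 4-methylpiperidin-1-yl rather than methylamino, so that step is only a partial guide. For the measured compounds named here, no measured step shows a 4-methylpiperidin-1-yl group at all.

On this basis compound 4 is expected to give a higher number than compound 3, a step estimated at a 1.8-fold higher number from compound 3 to compound 4 (0.25 log units; within the scatter). The estimate for compound 4 is 9000 nM, with a range from 2500 nM to 35000 nM.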

Compound 4, half-maximal inhibitory concentration: 600 nM
The estimate for compound 4 lay 15-fold (1.18 log units) above the measured number, outside the stated range (below it).
By their numbers in this assay, from the lowest: compound 2; then compound 4; then compound 1; then compound 3.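

The step of an 8.5-fold lower number from compound 3 to compound 4 (0.93 log units; beyond the scatter) shows that this aromatic carbon does not depend on sulfamoyl for a low number in this assay: with pyridin-4-yl on the shared core, a 4-methylpiperidin-1-yl group with its six-membered non-aromatic ring and no hydrogen-bond donor does better than sulfamoyl. Among the compounds shown here, until now the only step at this position, an 11-fold lower number from compound 1 to compound 2 (1.02 log units; beyond the scatter), had favoured sulfamoyl, but that was over methylamino and with pyridin-3-yl on the core, so the two steps together show that sulfamoyl is not favoured at this position under every circumstance. Nothing available here accounts for the direction of the new step.

The compounds shown leave open whether 4-methylpiperidin-1-yl would also lower the number with pyridin-3-yl on the core, where compound 2 with sulfamoyl already gives 200 nM, and so whether the effects of the two positions add up or depend on each other. They also leave open how much of the step belongs to the ring and how much to its methyl group, which a plain piperidine or a morpholine at the same carbon would begin to separate.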